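The source may report more compounds than this note shows. Statements on the series, on what has been measured and on what is new or still open speak of the compounds shown alone.

Results so far in an ADME assay on WI-38 cells (Homo sapiens) for cytotoxicity, read by MTT assay (a higher number here means a weaker inhibitor, a lower number a stronger inhibitor), are as follows
- Compound 1 `COc1cccc(-c2cc(-c3c(O)c4ccccc4oc3=O)nc(N)c2C#N)c1` gives 53800 nM
- Compound 2 `N#Cc1c(-c2ccc(F)cc2)cc(-c2c(O)c3ccccc3oc2=O)nc1N` gives "not determined" (no result reported)
- Compound 3 `COc1cccc(C2CC(c3c(O)c4ccccc4oc3=O)=NN2)c1` gives "not determined" (no result reported)

Compound 3 stands without a single number in this assay and compound 2 shares that position. For the measured compounds named here, that leaves compound 1 (53800 nM) as the only figure, and no measured step links any two compounds. The next structure to be tested is compound 4 `O=c1oc2ccccc2c(O)c1C1=NNC(c2ccc(F)cc2)C1` which has no result yet. The structural step 4-fluorophenyl in place of 3-methoxyphenyl on a saturated ring carbon puts 4-fluorophenyl in place of 3-methoxyphenyl on a saturated ring carbon.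

Nothing measured here shows what this exchange does in this assay so no step beyond the usual scatter is expected, in either direction, and any such expectation stays tentative while compound 3 lacks a number to start from. Going by the values given here, the single figure of compound 1 (53800 nM) is the only anchor for the level, and a loose one, so the expected range is kept wide. For compound 4 the estimated value is 50000 nM with an expected range from 15000 nM to 150000 nM in this measurement.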

Compound 4, half-maximal inhibitory concentration: 20000 nM
The estimate for compound 4 lay 2.5-fold (0.40 log units) above the measured number; measured number inside the range.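

In this assay, for the compounds shown here, compound 4 gives 20000 nM while compound 3 has no single number, so no step from compound 3 to compound 4 can be read. What 4-fluorophenyl in place of 3-methoxyphenyl does in this assay stays open for the compounds shown. No evidence is available to explain the value of compound 4.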